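Shortening the Amine Chain from Butyl to Propyl

The source may hold more compounds than are shown below. What is called first, only, known or untested is meant among the compounds shown, and "the series" means these compounds.

Compound 1 `CNCc1ccc(Cl)c(-c2ccccc2OC)c1` carries a bare secondary amine on its shared core. In an assay on isolated protein for binding affinity to 5-hydroxytryptamine receptor 1B (Homo sapiens) (on this read-out higher numbers stand for weaker inhibition and lower numbers for stronger inhibition), compound 1 gives 1200 nM. Compound 2 `CCCCNCc1ccc(Cl)c(-c2ccccc2OC)c1` carries a butyl group on that nitrogen instead. In this assay compound 2 reaches only the limit of > 10000 nM, so no number is known for it. The step of an at least 8.3-fold higher number from compound 1 to compound 2 (0.92 log units; beyond the scatter) therefore has only a lower bound, which rests on (the limit of > 10000 nM in this assay, at which 1 of the 2 values shown sits). Compound 2 thus stands at the weak end of the two measured compounds. Compound 3 `CCCNCc1ccc(Cl)c(-c2ccccc2OC)c1` differs from compound 2 by hydrogen in place of methyl on a saturated chain carbon, three bonds along the chain from an amine nitrogen, so that the butyl becomes a propyl. Within the data shown here, the only measured step that bears on this change is the addition of the whole butyl chain, an at least 8.3-fold higher number from compound 1 to compound 2 (0.92 log units; beyond the scatter), which went in the weakening direction. Removing one carbon of that chain is expected to return part of that loss, so a lower number than that of compound 2 is expected, though probably not back to the level of compound 1. The estimated step is an at least 2.0-fold lower number from compound 2 to compound 3 (0.30 log units; that floor lies within the scatter). Compound 3 is therefore estimated at 5000 nM, within 1500 nM to 15000 nM.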

Compound 3, inhibition constant: 640 nM
Estimate against measurement, compound 3: 7.8-fold (0.89 log units) above; the whole stated range lies above it.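

In this assay, cutting the butyl chain on the amine nitrogen back to propyl gives an at least 15-fold lower number from compound 2 to compound 3 (1.19 log units; beyond the scatter), so a single methyl, three bonds along the chain from an amine nitrogen, carries a large share of what separates the butyl compound from the others. The propyl chain itself costs nothing that can be read against the methyl on the amine of compound 1, since a 1.9-fold lower number from compound 1 to compound 3 (0.27 log units; within the scatter) leaves the two level within the scatter; the earlier step had suggested that chain length on this nitrogen weakens the value gradually, whereas these three compounds show no loss up to propyl and a large one at butyl. The size of the step from the butyl compound is only a floor, and the value of compound 2 is a limit, not a number: the limit of > 10000 nM in this assay, at which 1 of the 3 values shown sits.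

The compounds shown leave open how an ethyl chain on the same nitrogen would read, and whether a longer chain such as pentyl would stay as weak as butyl. They also leave open whether a branched chain such as isopropyl, or a tertiary amine carrying two such chains, would behave like propyl or like butyl.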